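This account rests on a few compounds, and the source may have more. Where it says the series, first, only, none or still open, it means among the compounds named here.

Compound 1 `COc1ccc2ncc(S(=O)(=O)c3ccc(C)c(F)c3)c(N3CCC(C)CC3)c2c1`: 73%
Compound 2 `COc1ccc2ncc(S(=O)(=O)c3ccc(Cl)cc3)c(N3CCC(C)CC3)c2c1`: 91%
Compound 3 `COc1ccc2ncc(S(=O)(=O)c3cc(F)cc(F)c3)c(N3CCC(C)CC3)c2c1`: 30%

These three numbers come from an assay on isolated protein for displacement of a labelled ligand from metabotropic glutamate receptor 5 (Homo sapiens), with a stated time of 60 min, tested at 1 uM; on this read-out lower numbers stand for less inhibition and higher numbers for more inhibition at the one concentration tested (going by the name of the read-out). Compound 3 stands lowest of the three, with compound 1 nearest and compound 2 furthest, both differences beyond the scatter. Compound 4 `COc1ccc2ncc(S(=O)(=O)c3cc(C)cc(C)c3)c(N3CCC(C)CC3)c2c1` differs from compound 3 in one place: 3,5-dimethylphenyl in place of 3,5-difluorophenyl on a sulfonyl sulfur. Among the measured compounds shown here, no measured step changes 3,5-difluorophenyl into 3,5-dimethylphenyl directly. The steps that touch the 3,5-difluorophenyl are a number 43 percentage points lower from compound 1 to compound 3 (beyond the scatter) and a number 61 percentage points lower from compound 2 to compound 3 (beyond the scatter), both large, and both arrive at the lowest number, so leaving that group is expected to move the number upward, probably by a modest to large step, though its size is uncertain. In this assay compound 4 is expected to give 60%, within 25% to 90%, an estimated step of a number 30 percentage points higher from compound 3 to compound 4 (beyond the scatter).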

Compound 4, a percentage reported as inhibition, at one concentration (the size of the read-out at that concentration, not a potency): 79%
Beside the measured number, compound 4's estimate is 19 percentage points below it; the range from low to high includes it.
By their numbers in this assay, from the lowest: compound 3; then compounds 1 and 4 (each within the scatter of the next); then compound 2.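

In this assay, 3,5-dimethylphenyl in place of 3,5-difluorophenyl gives a number 49 percentage points higher from compound 3 to compound 4 (beyond the scatter), so a ring with the same placement of its two groups on the sulfonyl sulfur can still give a high number, and the low value goes with the fluorines, not with that placement alone. Among the compounds shown here, the other comparisons give a number 6 percentage points higher from compound 1 to compound 4 (within the scatter) and a number 12 percentage points lower from compound 2 to compound 4 (beyond the scatter), leaving 4-chlorophenyl with the highest number so far. Nothing available explains these differences.

As far as these compounds go, whether 3,5-dichlorophenyl or 3,5-dimethoxyphenyl would also give a high number remains open. So does how these single-concentration percentages relate to the effect at other concentrations.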